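A Chloro Substituent Tested on Two Thromboxane Antagonist Cores

The compounds below may be only part of what the source reports. "The series", "measured", "known", "first", "only" and "open" are said of these compounds alone.

Compound 1, `CC(C)c1ccc2c(CCCCCS(=O)(=O)Nc3ccccc3)cc(S(=O)(=O)O)c-2cc1`, gives 1400 nM in a functional assay on thoracic aorta for antagonist activity at thromboxane A2 receptor (Rattus norvegicus); a higher number here means a weaker inhibitor, a lower number a stronger inhibitor.
Compound 2, `CC(C)c1ccc2c(CCCCCS(=O)(=O)Nc3ccc(Cl)cc3)cc(S(=O)(=O)O)c-2cc1`, gives 860 nM in this assay.
Compound 3, `CC(C)c1ccc2c(CCCC(=O)NS(=O)(=O)c3ccccc3)cc(C(=O)O)c-2cc1`, gives only a limit in this assay, > 100000 nM.

Compound 1 and compound 2 share one core, and compound 3 carries another; how the two cores differ is not broken down here. Compound 3 sits at the limit of > 100000 nM in this assay, at which 1 of the 3 values shown sits, so its result is a limit rather than a number. Compound 1 and compound 2 differ by chloro in place of hydrogen on an aromatic carbon, and that change produced a 1.6-fold lower number from compound 1 to compound 2 (0.21 log units; within the scatter) in this assay.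

Compound 4, `CC(C)c1ccc2c(CCCC(=O)NS(=O)(=O)c3ccc(Cl)cc3)cc(C(=O)O)c-2cc1`, has not yet been measured. It differs from compound 3 by chloro in place of hydrogen on an aromatic carbon, the same change already seen between compound 1 and compound 2. Because compound 3 gave only the limit > 100000 nM, and because the earlier step was a 1.6-fold lower number from compound 1 to compound 2 (0.21 log units; within the scatter), the expected step from compound 3 to compound 4 in this assay is a number no higher from compound 3 to compound 4 (the limit leaves the size open). Compound 4 is therefore expected to give about 100000 nM in this assay. Compound 4 is estimated to fall between 30000 nM and 300000 nM, most likely again as a limit.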

Compound 4, half-maximal inhibitory concentration: 19000 nM
Beside the measured number, compound 4's estimate is 5.3-fold (0.72 log units) above it, and the stated range ends above it.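

On the core of compound 3, going from phenylsulfonyl to (4-chlorophenyl)sulfonyl gave an at least 5.2-fold lower number from compound 3 to compound 4 (0.72 log units; beyond the scatter) in this assay. The same change therefore did not carry over at the same size from one core to the other: the same change on two cores in this assay, a 1.6-fold lower number (0.21 log units; within the scatter) from compound 1 to compound 2 and an at least 5.2-fold lower number (0.72 log units; beyond the scatter) from compound 3 to compound 4, at least 3.2-fold (0.50 log units) apart, beyond the scatter of two such steps

The value of compound 3, > 100000 nM, is a limit and not a number, so the true size of its step remains unknown, and two cores neither explain the gap nor predict what chloro would do on a third core.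

The compounds shown leave open whether another group in the same place, such as fluoro, methyl or methoxy, would follow chloro on either core. They also leave open which of the differences between the two cores governs the size of the step, and whether a chloro placed elsewhere on the ring, or a longer chain on the core of compound 3, would alter it.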